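Acetamido replaces cyclohexylcarbonylaminomethyl on the amide arm

A few compounds are considered here, and "the series" means these few. Any claim that something is new, unique, unknown or untested is made for them only; others in the source may bear on it.

For the measured compounds named here, compound 2 `Nc1ncccc1-c1nc2cccnc2n1-c1ccc(CNC(=O)C2CCCCC2)cc1` gives 250 nM in an in vitro assay on Sf9 cells for inhibition of RAC-alpha serine/threonine-protein kinase (Homo sapiens), read by AlphaScreen, with a stated time of 20 min (a lower number here means a stronger inhibitor, a higher number a weaker inhibitor), the higher of the two numbers measured so far, while compound 1 `Nc1ncccc1-c1nc2cccnc2n1-c1ccc(NC(=O)c2ccccc2)cc1` gives 14 nM. Going by the values given here, the single measured step, an 18-fold higher number from compound 1 to compound 2 (1.25 log units; beyond the scatter), concerns the same arm that changes again here. Compound 3 `CC(=O)Nc1ccc(-n2c(-c3cccnc3N)nc3cccnc32)cc1` differs from compound 2 by acetamido in place of ((cyclohexylcarbonyl)amino)methyl on an aromatic carbon. Since compound 1 with its benzamido group gave 14 nM, an amide set directly on the ring goes with the lower number, and compound 3 shares that arrangement. Compound 3 is therefore expected to give 60 nM (range 15 nM to 250 nM), an estimated step of a 4.2-fold lower number from compound 2 to compound 3 (0.62 log units; beyond the scatter).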

Compound 3, half-maximal inhibitory concentration: 1300 nM
Compound 3: the middle estimate sits 22-fold (1.34 log units) below what was measured; measured number above the stated range.
By their numbers in this assay, from the lowest: compound 1; then compound 2; then compound 3.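

In this assay an amide set directly on the ring is not enough for a low number: methyl in place of phenyl on the carbonyl carbon brings a 93-fold higher number from compound 1 to compound 3 (1.97 log units; beyond the scatter) at this position. Acetamido in place of ((cyclohexylcarbonyl)amino)methyl brings a 5.2-fold higher number from compound 2 to compound 3 (0.72 log units; beyond the scatter) here, so among these three compounds the two arms carrying a ring go with the lower numbers. Nothing available on these compounds explains either step.

Still open, going by these compounds, is whether a longer chain on the carbonyl carbon would restore the lower numbers without a ring. Also open, on these data alone, is how an amine or a carboxylic acid on that arm would read.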